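From a Methylfuran to a Methylisothiazole on the Shared Core

A few compounds are considered here, and "the series" means these few. Any claim that something is new, unique, unknown or untested is made for them only; others in the source may bear on it.

The account starts from compound 3 `Cc1ccoc1-c1ccccc1OCC1=NCCN1`. In a functional assay for activation of Alpha-1D adrenergic receptor (Homo sapiens), read by calcium flux (on this read-out lower numbers stand for an effect already at smaller amounts and higher numbers for an effect only at larger amounts of compound), compound 3 gives < 100000 nM, which is a limit of the assay and not a number. Compound 1 `c1coc(-c2ccccc2OCC2=NCCN2)c1` gives < 100000 nM in this assay, again only a limit. Compound 2 `c1ccc(-c2ncc[nH]2)c(OCC2=NCCN2)c1` gives < 100000 nM, also a limit. The whole set thus rests on the limit of < 100000 nM in this assay, at which 3 of the 3 values shown sit: none of the three stands on a readable number, and the steps a step that the two limits leave unreadable from compound 1 to compound 2, a step that the two limits leave unreadable from compound 1 to compound 3 and a step that the two limits leave unreadable from compound 2 to compound 3 can be given neither a size nor a direction. The unmeasured compound 4 `Cc1cnsc1-c1ccccc1OCC1=NCCN1` differs from compound 3 by 4-methyl-1,2-thiazol-5-yl in place of 3-methylfuran-2-yl on an aromatic carbon. No measured step bears on this change in a readable way, since every shown value is a limit. The expectation for compound 4 is therefore that it keeps company with its neighbours, with a step that the limit leaves unreadable from compound 3 to compound 4 expected to be no step beyond the scatter. Compound 4 is estimated at 5000 nM, within the range 100 nM to 100000 nM, and it is expected that this assay most likely reports only a limit for it again.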

Compound 4, half-maximal effective concentration: < 100000 nM
Compound 4 gave a limit, no number; the forecaster's own chance of this, stated with the estimate: 75%; the middle value is on the limit's open side.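

Compound 4 gives only a limit, so no step between compound 4 and compound 1, compound 2 or compound 3 can be read: the limit of < 100000 nM in this assay, at which 4 of the 4 values shown sit.

Going by these compounds, whether 4-methyl-1,2-thiazol-5-yl in place of 3-methylfuran-2-yl changes this read-out at all, and how the four compounds rank, stays open.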